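Carboxyphenyl Amide Replaces Methoxyamide in a Bcl-2 Series

The source may hold more compounds than are shown below. What is called first, only, known or untested is meant among the compounds shown, and "the series" means these compounds.

The study works on a shared core carrying a phenyl ring and a carboxamide, tested in an assay on isolated protein for inhibition of Apoptosis regulator Bcl-2 (Homo sapiens), read by fluorescence polarization, with stated times of 5 min and 10 min; a lower number here means a stronger inhibitor, a higher number a weaker inhibitor. Compound 1 `CON(C)C(=O)[C@H]1CC2=C(CCCC2(C)C)C[C@@H]1c1ccccc1` is reported only as a limit of this assay, > 23000 nM. Compound 2 `COC(=O)c1ccc(NC(=O)[C@H]2CC=C(CCC=C(C)C)C[C@@H]2c2ccccc2)cc1` likewise reaches only a limit of this assay, > 23000 nM. Within the data shown here, compound 3 `CONC(=O)[C@@H]1CC=C(CCC=C(C)C)C[C@H]1c1ccccc1` is the single compound with a number in this assay, 2700 nM, so it stands alone among the values shown, while the other two values sit at the limit of > 23000 nM in this assay, at which 2 of the 3 values shown sit.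

The step to compound 4 `CC(C)=CCCC1=CC[C@@H](C(=O)Nc2ccc(C(=O)O)cc2)[C@H](c2ccccc2)C1` changes only the amide substituent: 4-carboxyphenyl in place of methoxy on an amide-type nitrogen. Among the measured compounds shown here, no measured pair in this set shares that change, so its size can only be estimated. Two of the three values shown sit at the limit, which leaves considerable room for compound 4 to fall out of range as well. The author expects the step in this assay from compound 3 to compound 4 to be about a 1.9-fold higher number from compound 3 to compound 4 (0.27 log units; within the scatter), a modest loss that may not exceed the scatter. Compound 4 is therefore expected to give 5000 nM, within a range of 1000 nM to 25000 nM.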

Compound 4, inhibition constant: 2200 nM
Estimate against measurement, compound 4: 2.3-fold (0.36 log units) above, within the range that was stated.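

In this assay, the exchange gives a 1.2-fold lower number from compound 3 to compound 4 (0.09 log units; within the scatter), so the amide-type nitrogen keeps a measurable value with 4-carboxyphenyl, a group with an aromatic ring, in place of the much smaller methoxy. Compound 2 differs from compound 4 only in carrying the methyl ester in place of the carboxylic acid on that phenyl ring. Compound 2 is reported only as a limit, > 23000 nM. Among these compounds, no step to compound 4 can be read from that limit, but together these compounds show that a phenyl ring on this nitrogen does not by itself ensure a number in the assay, and that the outcome here depends on what the ring carries.

As far as these compounds go, whether an amine or a tetrazole in place of the carboxylic acid would give a number, and whether the carboxylic acid would do so if moved elsewhere on the phenyl ring or set on a longer chain, stays open. Only compound 3 and compound 4 carry numbers, and the remainder of the set gives no size for any other change: the limit of > 23000 nM in this assay, at which 2 of the 4 values shown sit.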